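The compounds below may be only part of what the source reports. "The series", "measured", "known", "first", "only" and "open" are said of these compounds alone.

Compound 1 `CCN(CC)CCNC(=O)c1ccc(C(CC)(CC)c2ccc(OCCC(O)(CC)CC)c(C)c2)n1CC`: 230 nM
Compound 2 `CCOc1ccc(NC(=O)c2ccc(C(CC)(CC)c3ccc(OCCC(O)(CC)CC)c(C)c3)n2CC)cc1`: > 50000 nM
Compound 3 `CCOC(=O)CN(C)C(=O)c1ccc(C(CC)(CC)c2ccc(OCCC(O)(CC)CC)c(C)c2)n1CC`: not yet measured

In a functional assay on HepG2 cells (Homo sapiens) for antiproliferative activity, read by MTT assay, with a stated time of 48 h (on this read-out higher numbers stand for weaker inhibition and lower numbers for stronger inhibition), compound 2 reads > 50000 nM, which is a limit of the assay and not a number. Compound 3 replaces (4-ethoxyphenyl)amino on the carbonyl carbon with ((ethoxycarbonyl)methyl)(methyl)amino: ((ethoxycarbonyl)methyl)(methyl)amino in place of (4-ethoxyphenyl)amino on a carbonyl carbon. For the measured compounds named here, one measured step bears on this: an at least 210-fold higher number from compound 1 to compound 2 (2.33 log units; beyond the scatter), large and beyond the scatter. Like compound 2, compound 3 lacks the 2-(diethylamino)ethyl group of compound 1, which gives 230 nM, so a return to that level is not expected. The expected change is only modest, towards lower numbers: an estimated at least 2.0-fold lower number from compound 2 to compound 3 (0.30 log units; that floor lies within the scatter). A reading at the limit remains possible. In this assay the estimate for compound 3 is 25000 nM, with an expected range of 6000 nM to 80000 nM.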

Compound 3, half-maximal inhibitory concentration: 25300 nM
Beside the measured number, compound 3's estimate is 1.0-fold (0.01 log units) below it, within the range that was stated.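

In this assay, ((ethoxycarbonyl)methyl)(methyl)amino in place of (4-ethoxyphenyl)amino on the carbonyl carbon gives an at least 1.9-fold lower number from compound 2 to compound 3 (0.29 log units; that floor lies within the scatter), so no real gain can be claimed for this change. Compound 2 stands at a limit of the assay, not at a number: the limit of > 50000 nM in this assay, at which 1 of the 3 values shown sits. The new point lies in the other comparison, a 110-fold higher number from compound 1 to compound 3 (2.04 log units; beyond the scatter): a group with no ring and no amide hydrogen also falls far short of (2-(diethylamino)ethyl)amino, so the large loss is not tied to the 4-ethoxyphenyl group alone.

Still open, on these data alone, is which part of the (2-(diethylamino)ethyl)amino group matters in this assay. A 2-(dimethylamino)ethyl or 2-morpholinoethyl group on the amide nitrogen, or a carboxylic acid in place of the ethyl ester, would help to separate these parts.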